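From Bromo to Methoxy: One Small Swap Awaiting Its Number

The source may report more compounds than this note shows. Statements on the series, on what has been measured and on what is new or still open speak of the compounds shown alone.

In an ADME assay on HMEC cells (Homo sapiens) for cytotoxicity, read by MTT assay (on this read-out lower numbers stand for stronger inhibition and higher numbers for weaker inhibition), compound 1 `Nc1ccccc1NC(=O)c1ccc(CNc2nc3ccc(Br)cc3s2)cc1` gives 6000 nM and compound 2 `COc1ccc2nc(SCc3ccc(C(=O)Nc4ccccc4N)cc3)[nH]c2c1` gives 10000 nM, so the two numbers lie within the usual scatter of each other. Compound 3 `COc1ccc2nc(NCc3ccc(C(=O)Nc4ccccc4N)cc3)sc2c1` has not yet been measured. It differs from compound 1 by a single swap, methoxy in place of bromo on an aromatic carbon. Within the data shown here, no measured pair shows such a swap, and no step beyond the scatter is expected in this assay. The expected change is small: a 1.3-fold higher number from compound 1 to compound 3 (0.12 log units; within the scatter). For compound 3 the estimated value is 8000 nM, with an expected range of 3000 nM to 20000 nM.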

Compound 3, half-maximal inhibitory concentration: 5000 nM
Compound 3: the middle estimate sits 1.6-fold (0.20 log units) above what was measured; measured number inside the range.
By their numbers in this assay, from the lowest: compounds 3, 1 and 2 (each within the scatter of the next).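

In this assay, among these compounds, methoxy in place of bromo on this aromatic carbon gives a 1.2-fold lower number from compound 1 to compound 3 (0.08 log units; within the scatter), the first measured pair to show this swap. The two compounds cannot be told apart on this read-out, even though the entering group has one more heavy atom and brings a hydrogen-bond acceptor. Nothing available explains this result. Going by these compounds, whether an amine or a carboxylic acid on the same carbon would also stay within the scatter remains open. The same question holds for a longer chain, such as ethoxy.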